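The source may hold more compounds than are shown below. What is called first, only, known or untested is meant among the compounds shown, and "the series" means these compounds.

Compound 3 `CC1=C(C(=O)Nc2ccc(C)cc2)C(c2cn(-c3ccccc3)nc2-c2ccccc2)NC(=O)N1` gives 71700 nM in a functional assay on MCF7 cells (Homo sapiens) for inhibition, read by sulforhodamine B assay, with a stated time of 24 h (on this read-out higher numbers stand for weaker inhibition of growth and lower numbers for stronger inhibition of growth), which places it second highest of the three numbers measured. Its neighbours are compound 1 `CCOC(=O)C1=C(C)NC(=O)NC1c1cn(-c2ccccc2)nc1-c1ccccc1`, at 60800 nM, and compound 2 `CC1=C(C(=O)Nc2ccccc2)C(c2cn(-c3ccccc3)nc2-c2ccccc2)NC(=O)N1`, at 80600 nM; the step of a 1.2-fold higher number from compound 1 to compound 3 (0.07 log units; within the scatter) and the step of a 1.1-fold lower number from compound 2 to compound 3 (0.05 log units; within the scatter) both stay within the scatter, as does a 1.3-fold higher number from compound 1 to compound 2 (0.12 log units; within the scatter). Compound 4 `CC1=C(C(=O)Nc2ccccc2Cl)C(c2cn(-c3ccccc3)nc2-c2ccccc2)NC(=O)N1` differs from compound 3 by 2-chlorophenyl in place of 4-methylphenyl on an amide-type nitrogen. For the measured compounds named here, the one comparable change on this amide nitrogen, from compound 2 to compound 3, moved nothing beyond the scatter, so the expectation is that compound 4 also stays close to compound 3, with an expected step of a 1.0-fold higher number from compound 3 to compound 4 (0.02 log units; within the scatter). The estimate for compound 4 is 75000 nM, within the range 38000 nM to 150000 nM.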

Compound 4, concentration for 50% growth inhibition: 66600 nM
Estimate against measurement, compound 4: 1.1-fold (0.05 log units) above; low and high end bracket the measured number.
By their numbers in this assay, from the lowest: compounds 1, 4, 3 and 2 (each within the scatter of the next).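

Replacing 4-methylphenyl with 2-chlorophenyl on the amide-type nitrogen gives a 1.1-fold lower number from compound 3 to compound 4 (0.03 log units; within the scatter) and chloro in place of hydrogen gives a 1.2-fold lower number from compound 2 to compound 4 (0.08 log units; within the scatter), so phenyl, 4-methylphenyl and 2-chlorophenyl on this nitrogen all read alike. Exchanging ethoxy for (2-chlorophenyl)amino also changes little, with a 1.1-fold higher number from compound 1 to compound 4 (0.04 log units; within the scatter) as the step. No supporting measurement explains this flat result. From the compounds shown here alone, it remains open whether a carboxylic acid or an amine on this phenyl ring, or a longer chain in place of the ring, would move the number beyond the scatter.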